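The source may hold more compounds than are shown below. What is called first, only, known or untested is meant among the compounds shown, and "the series" means these compounds.

Working notes on the series. In a functional assay on MCF7 cells (Homo sapiens) for cytotoxicity, read by MTT assay, with a stated time of 72 h (on this read-out higher numbers stand for weaker inhibition and lower numbers for stronger inhibition), compound 1 `Cc1cc(=O)n(-c2ccc(F)cc2)nc1C(=O)Nc1ccc(Oc2ncnc3ccsc23)cc1` gives 4400 nM. Compound 2 `Cc1ccc(-n2nc(C(=O)Nc3ccc(Oc4ncnc5sccc45)cc3)c(C)cc2=O)cc1` shares the amide and the aryl ether with compound 1 but carries a different fused bicyclic core and a methylphenyl on the pyridazinone nitrogen. Among the measured compounds shown here, for compound 2 this assay returns only a limit, > 40000 nM, so where compound 2 stands is known solely as the limit of > 40000 nM in this assay, at which 1 of the 2 values shown sits: no number for it, and no measured step to compare against compound 1.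

Compound 3 `Cc1cc(=O)n(-c2ccc(F)cc2)nc1C(=O)Nc1ccc(Oc2ncnc3sccc23)cc1` is compound 2 with fluoro in place of methyl on an aromatic carbon, a change that brings the pyridazinone substituent into line with compound 1 while keeping the core of compound 2. Since compound 2 stands only as a limit, the size of the step to compound 3 cannot be set from a measured pair. The expectation is a step toward stronger inhibition, an at least 2.6-fold lower number from compound 2 to compound 3 (0.42 log units; beyond the scatter), because compound 1 gives 4400 nM with the same fluorophenyl. Compound 3 is therefore estimated at 15000 nM, with a range from 3000 nM to 60000 nM.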

Compound 3, half-maximal inhibitory concentration: 21000 nM
Beside the measured number, compound 3's estimate is 1.4-fold (0.15 log units) below it, within the range that was stated.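

In this assay, 4-fluorophenyl in place of 4-methylphenyl gives an at least 1.9-fold lower number from compound 2 to compound 3 (0.27 log units; that floor lies within the scatter), so the change at this place, para to a large group, has no measured size and only a floor. The step is open-ended because compound 2 stands as a limit: the limit of > 40000 nM in this assay, at which 1 of the 3 values shown sits.

Among the compounds shown here, with 4-fluorophenyl held fixed, the change of fused bicyclic core alone gives a 4.8-fold higher number from compound 1 to compound 3 (0.68 log units; beyond the scatter), the first step with a full measured size, and it shows that the core arrangement alters the read-out on its own.

On these data alone, how 4-methylphenyl behaves on the core of compound 1 stays open, so whether the two changes add up cannot be told. Also open, as far as these compounds go, is what an amine or a carboxylic acid in the same place would do to the number on either core.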